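The source may report more compounds than this note shows. Statements on the series, on what has been measured and on what is new or still open speak of the compounds shown alone.

Measured compounds in an assay on isolated protein for inhibition of leukotriene C4 synthase (Homo sapiens), read by LC-MS, with stated times of 45 min and 20 min; on this read-out higher numbers stand for weaker inhibition and lower numbers for stronger inhibition:
Compound 1 `COc1cc(N(CC2CC2)c2ccc(Cl)c3ccccc23)cnc1C(=O)[C@H]1C[C@@H]1C(=O)O` — compound 1 gives 9.41 nM
Compound 2 `COc1cc(N(CC2CC2)c2ccc(F)c3ccccc23)cnc1C(=O)[C@H]1C[C@@H]1C(=O)O` — compound 2 gives 26.5 nM
Compound 3 `COc1cc(N(CC(C)C)c2ccc(F)c3ccccc23)cnc1C(=O)[C@H]1C[C@@H]1C(=O)O` — compound 3 gives 2.26 nM

Compound 3 holds the lowest number of the three in this assay. Compound 1 stands above it and compound 2 further above; the steps to both are beyond the scatter, so compound 3 is the strongest inhibitor of the set so far. Two single-point steps connect the measured compounds: a 2.8-fold higher number from compound 1 to compound 2 (0.45 log units; beyond the scatter), and a 12-fold lower number from compound 2 to compound 3 (1.07 log units; beyond the scatter). The second step, at the saturated chain carbon bound to the aromatic nitrogen, is the one that bears on the next compound.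

Compound 4 `CCCN(c1cnc(C(=O)[C@H]2C[C@@H]2C(=O)O)c(OC)c1)c1ccc(F)c2ccccc12` differs from compound 3 by hydrogen in place of methyl on a saturated chain carbon bound to two saturated chain carbons; read one bond further out, isobutyl on the nitrogen becomes propyl. Among the compounds with values here, the only measured change at this part of the molecule is the large one from compound 2 to compound 3, which swapped a ring for an open branched chain; no measured pair shows the loss of a single methyl from that chain. Removing the branch is therefore expected to cost some potency, but less than the whole of that step: a 2.7-fold higher number from compound 3 to compound 4 (0.42 log units; beyond the scatter) is the expected move. Compound 4 is estimated at 6 nM, with a range from 2 nM to 20 nM.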

Compound 4, half-maximal inhibitory concentration in the leukotriene C4 synthase assay: 7.09 nM
Beside the measured number, compound 4's estimate is 1.2-fold (0.07 log units) below it, and the stated range covers the measured number.
By their numbers in the leukotriene C4 synthase assay, from the lowest: compound 3; then compounds 4 and 1 (each within the scatter of the next); then compound 2.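

In the leukotriene C4 synthase assay, the single methyl of the isobutyl branch turns out to matter on its own: a 3.1-fold higher number from compound 3 to compound 4 (0.50 log units; beyond the scatter). Opening the ring without keeping the branch still gives a gain in the leukotriene C4 synthase assay, with ethyl in place of cyclopropyl: a 3.7-fold lower number from compound 2 to compound 4 (0.57 log units; beyond the scatter); the large step seen earlier, a 12-fold lower number from compound 2 to compound 3 (1.07 log units; beyond the scatter), therefore divides at this position into a part that comes with the open chain and a part that comes with the branch. In a physicochemical assay for lipophilicity, read by LC-MS, in phosphate buffer, measured as octanol-water partition, at pH 7.4 (on this read-out higher numbers stand for higher lipophilicity and lower numbers for lower lipophilicity), compound 3 gives 2.2 and compound 4 gives 1.8; the same loss of the methyl goes with lower lipophilicity, so that for this one pair weaker inhibition and a lower distribution coefficient arrive together, though a single pair cannot separate the two: the measured distribution coefficient of compound 3, 2.2, and of compound 4, 1.8, a number 0.40 log units lower (beyond the scatter)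

As far as these compounds go, whether a butyl chain or a hydroxyethyl chain in place of propyl would continue this trend in the leukotriene C4 synthase assay remains open, as does how far inhibition follows the distribution coefficient beyond this pair. Also open, from the compounds shown here alone, is whether chloro in place of fluoro, so far read only in the cyclopropyl pair, would carry over to the isobutyl and propyl compounds.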